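This account rests on a few compounds, and the source may have more. Where it says the series, first, only, none or still open, it means among the compounds named here.

In an ADME assay on the whole organism (plasma, strain 129/SvEvBrd x C57BL/6) for pharmacokinetics, with Mus musculus as the target, at a dose of 10 mg/kg by the oral route (on this read-out lower numbers stand for lower exposure and higher numbers for higher exposure at the dose given), compound 1 (`OC[C@@H](O)[C@@H](O)[C@H](O)c1c[nH]c(-c2ncc[nH]2)n1`) gives 1500 ng.h/mL and compound 2 (`OC[C@@H](O)[C@@H](O)[C@H](O)c1c[nH]c(-c2ncccn2)n1`) gives 799 ng.h/mL so the two stand within the scatter of each other. Compound 3 (`OC[C@@H](O)[C@@H](O)[C@H](O)c1c[nH]c(-c2ncon2)n1`) carries 1,2,4-oxadiazol-3-yl in place of pyrimidin-2-yl on an aromatic carbon of the shared core. Among the measured compounds shown here, the only measured exchange at this place gave a 1.9-fold lower number from compound 1 to compound 2 (0.27 log units; within the scatter) and so no step beyond the scatter is expected here. The estimated outcome is a 1.1-fold lower number from compound 2 to compound 3 (0.06 log units; within the scatter) in this assay for this exchange. Compound 3 is estimated at 700 ng.h/mL with an expected range of 250 ng.h/mL to 1800 ng.h/mL around that middle.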

Compound 3, area under the concentration-time curve: 820 ng.h/mL
Compound 3: middle estimate off by 1.2-fold (0.07 log units), on the low side; the measured number falls inside the stated range.
By their numbers in this assay, from the lowest: compounds 2, 3 and 1 (each within the scatter of the next).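

In this assay, the five-membered 1,2,4-oxadiazol-3-yl replaces the six-membered pyrimidin-2-yl with a 1.0-fold higher number from compound 2 to compound 3 (0.01 log units; within the scatter) and no step beyond the scatter appears. Replacing 1H-imidazol-2-yl with the same group gives a 1.8-fold lower number from compound 1 to compound 3 (0.26 log units; within the scatter) and so also stays within the scatter, which means that all three aromatic rings at this place now lie within the scatter of one another. No measured evidence explains this result.

On these data alone, whether an amine, a carboxylic acid or a longer chain at this place would give a step beyond the scatter remains open.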